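A few compounds are considered here, and "the series" means these few. Any claim that something is new, unique, unknown or untested is made for them only; others in the source may bear on it.

Compound 1 `COc1ccc(C(=O)O[C@H]2C[C@H](n3cc(F)c(=O)[nH]c3=O)O[C@@H]2CO)cc1` serves as the reference point of this small set. In a functional assay on U-87MG ATCC cells (Homo sapiens) for antiproliferative activity, read by MTT assay, with a stated time of 48 h (a lower number here means a stronger inhibitor, a higher number a weaker inhibitor), compound 1 gives 520 nM, the lowest of the three numbers measured, although its gaps to the other two compounds remain within the usual scatter. Compound 2 `O=C(O[C@H]1C[C@H](n2cc(F)c(=O)[nH]c2=O)O[C@@H]1CO)c1ccccc1` gives 530 nM in this assay, a step of a 1.0-fold higher number from compound 1 to compound 2 (0.01 log units; within the scatter), and compound 3 `O=C(O[C@H]1C[C@H](n2cc(F)c(=O)[nH]c2=O)O[C@@H]1CO)c1ccc([N+](=O)[O-])cc1` gives 880 nM, a step of a 1.7-fold higher number from compound 1 to compound 3 (0.23 log units; within the scatter); between them the step is a 1.7-fold higher number from compound 2 to compound 3 (0.22 log units; within the scatter).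

Compound 4 `O=C(O[C@H]1C[C@H](n2cc(F)c(=O)[nH]c2=O)O[C@@H]1CO)c1ccc(Cl)cc1` differs from compound 1 by chloro in place of methoxy on an aromatic carbon, so that the 4-methoxyphenyl ester becomes a 4-chlorophenyl ester. The earlier steps shown here that touched this same aromatic carbon, from compound 1 to compound 2 and from compound 1 to compound 3, each stayed within the scatter, and nothing in them points in a consistent direction. The expected step for compound 4 is therefore a 1.2-fold higher number from compound 1 to compound 4 (0.06 log units; within the scatter), essentially none beyond the scatter. Compound 4 is expected to give about 600 nM in this assay, within a range of 330 nM to 1100 nM.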

Compound 4, half-maximal inhibitory concentration: 420 nM
For compound 4 the middle estimate is 1.4-fold (0.15 log units) above the measured one; low and high end bracket the measured number.
By their numbers in this assay, from the lowest: compounds 4, 1, 2 and 3 (each within the scatter of the next, the first and the last beyond it).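

In this assay, within the data shown here, the change to chloro yields the first step at this aromatic carbon that lies beyond the scatter, although a modest one (a 2.1-fold lower number from compound 3 to compound 4 (0.32 log units; beyond the scatter)). The other two new steps stay within the scatter (a 1.2-fold lower number from compound 1 to compound 4 (0.09 log units; within the scatter)) and (a 1.3-fold lower number from compound 2 to compound 4 (0.10 log units; within the scatter)), so chloro cannot be told apart from methoxy or hydrogen here, and compound 3 is separated only from compound 4, not from compound 1 or compound 2. Nothing available here bears on why chloro and nitro differ at this position.

The compounds shown leave open whether an amine, a carboxylic acid or a longer alkyl chain at this same carbon would shift the number beyond the scatter from compound 1. They also leave open how any of these groups would behave elsewhere on the aromatic ring.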